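Trifluoromethyl in Place of Hydroxy on a Shared Core

The source may hold more compounds than are shown below. What is called first, only, known or untested is meant among the compounds shown, and "the series" means these compounds.

Measured so far:
compound 1, `Oc1cccc(CNc2cc(Br)cc3[nH]ncc23)c1`, 55%
compound 2, `Nc1ccc(CNc2cc(Br)cc3[nH]ncc23)cc1`, 24%

In an assay for inhibition of Tryptophan 2,3-dioxygenase (Homo sapiens), with a stated time of 1 h, tested at 10 uM (on this read-out higher numbers stand for more inhibition at the one concentration tested (going by the name of the read-out) and lower numbers for less inhibition), compound 1 gives the higher of the two numbers, and compound 2, its nearest neighbour, sits well below it, a gap beyond the scatter. Compound 3, `FC(F)(F)c1cccc(CNc2cc(Br)cc3[nH]ncc23)c1`, has not yet been measured. It differs from compound 1 in one place: trifluoromethyl in place of hydroxy on an aromatic carbon. Going by the values given here, no measured pair shows such an exchange, so the size of the step in this assay can only be guessed. A moderate decrease is expected, roughly a number 20 percentage points lower from compound 1 to compound 3 (beyond the scatter). Compound 3 is therefore expected to reach about 35%, within 10% to 65%.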

Compound 3, a percentage reported as inhibition, at one concentration (the size of the read-out at that concentration, not a potency): 56%
Estimate against measurement, compound 3: 21 percentage points below, within the range that was stated.
By their numbers in this assay, from the lowest: compound 2; then compounds 1 and 3 (each within the scatter of the next).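

In this assay, trifluoromethyl in place of hydroxy on this aromatic carbon gives a number 1 percentage points higher from compound 1 to compound 3 (within the scatter). The hydrogen-bond donor and acceptor counted on hydroxy are absent from trifluoromethyl, yet the two compounds cannot be told apart here, so hydroxy is not required at this position for this level of inhibition. No measurement available explains this result.

From the compounds shown here alone, whether a methoxy group, an amine or a carboxylic acid on this same carbon would read alike stays open. A single concentration also leaves open whether compound 1 and compound 3 match in potency.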